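A few compounds are considered here, and "the series" means these few. Any claim that something is new, unique, unknown or untested is made for them only; others in the source may bear on it.

In a physicochemical assay for solubility, at pH 7 (a higher number here means a more soluble compound, a lower number a less soluble compound), compound 1 `CN1CCC(C(=O)N2Cc3c(NC(=O)C4CC4)n[nH]c3C2(C)C)CC1` gives > 225000 nM, a limit of the assay and not a number. Compound 2 `CC(C)(C)C(=O)N1Cc2c(NC(=O)C3CCNCC3)n[nH]c2C1(C)C` gives > 225000 nM, which is also a limit. Compound 3 `CC1(C)c2[nH]nc(NC(=O)c3ccc(F)cc3)c2CN1C(=O)C1CCN(C2CC2)CC1` gives > 225000 nM, again a limit. The whole picture so far is therefore (the limit of > 225000 nM in this assay, at which 3 of the 3 values shown sit), so no exact reading exists for compound 1 or for the other two. Among the measured compounds shown here, no measured pair that differs in one place is available as a guide either.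

Compound 4 `CN1CCC(C(=O)N2Cc3c(NC(=O)c4ccc5ccccc5c4)n[nH]c3C2(C)C)CC1` keeps the core of compound 1 and changes one group: naphthalen-2-yl in place of cyclopropyl on a carbonyl carbon. In words, naphthalen-2-yl stands in place of cyclopropyl on a carbonyl carbon, so 2 six-membered aromatic rings replace one three-membered ring.

On this structural change alone, a moderate fall in this assay is expected, although a result still at the limit remains quite possible. The estimated change is an at least 1.8-fold lower number from compound 1 to compound 4 (0.27 log units; that floor lies within the scatter). For compound 4 the expected value is 120000 nM, with an estimated range from 30000 nM to 225000 nM.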

Compound 4, solubility: 219000 nM
Estimate against measurement, compound 4: 1.8-fold (0.26 log units) below; measured number inside the range.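

With naphthalen-2-yl on this carbonyl carbon in place of cyclopropyl, this assay gives its first reading that is a number and not a limit: compound 4 gives 219000 nM. The change is an at least 1.0-fold lower number from compound 1 to compound 4 (0.01 log units; that floor lies within the scatter), so the swap of one three-membered ring for 2 six-membered aromatic rings has only a floor for its size, and that floor shows no clear fall. Compound 1 has no exact reading to set against compound 4: the limit of > 225000 nM in this assay, at which 3 of the 4 values shown sit.

From the compounds shown here alone, the true size of the step therefore stays open, and it could be small or larger than this floor shows. Also open, going by these compounds, is how a carboxylic acid or a longer carbon chain would read on this same carbonyl carbon of the shared core.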